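Cytotoxicity in fibroblasts: a sulfonamide replaces a chloroethyl chain

The source may hold more compounds than are shown below. What is called first, only, known or untested is meant among the compounds shown, and "the series" means these compounds.

Compound 1 `CCCCc1cn(C[C@H](O)[C@H]2OC(=O)C(OCc3ccccc3)=C2OCc2ccccc2)nn1`: 26300 nM
Compound 2 `O=C1O[C@H]([C@@H](O)Cn2cc(CCCCl)nn2)C(OCc2ccccc2)=C1OCc1ccccc1`: 27100 nM

Of the compounds shown here, two sharing one core have been measured in an ADME assay on HFF cells (Homo sapiens) for cytotoxicity, read by MTT assay, with a stated time of 72 h; a higher number here means a weaker inhibitor, a lower number a stronger inhibitor. Compound 1 gives 26300 nM, and compound 2 gives 27100 nM; the two numbers lie within the scatter of each other, so compound 2 does not stand apart from compound 1. Going by the values given here, the only measured step, a 1.0-fold higher number from compound 1 to compound 2 (0.01 log units; within the scatter), touches a single chain atom and showed no change beyond the scatter.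

Compound 3 `O=C1O[C@H]([C@@H](O)Cn2cc(CNS(=O)(=O)c3ccc(Cl)cc3F)nn2)C(OCc2ccccc2)=C1OCc1ccccc1` carries ((4-chloro-2-fluorophenyl)sulfonyl)amino in place of 2-chloroethyl on a saturated chain carbon bound to an aromatic carbon. Among the compounds with values here, the one measured step bears on this change only loosely, since it altered far less of the chain; it gives no ground for expecting a shift in either direction. Compound 3 is therefore expected to give 25000 nM, in a range from 8000 nM to 80000 nM, and the expected step of a 1.1-fold lower number from compound 2 to compound 3 (0.04 log units; within the scatter) is estimated to stay within the scatter.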

Compound 3, half-maximal inhibitory concentration: 20 nM
For compound 3 the middle estimate is 1300-fold (3.10 log units) above the measured one, and the stated range ends above it.
By their numbers in this assay, from the lowest: compound 3; then compounds 1 and 2 (each within the scatter of the next).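

The same chain, which showed nothing beyond the scatter when chloro stood in place of methyl, proves able to move this assay a long way: ((4-chloro-2-fluorophenyl)sulfonyl)amino in place of 2-chloroethyl gives a 1400-fold lower number from compound 2 to compound 3 (3.13 log units; beyond the scatter), on a saturated chain carbon bound to an aromatic carbon. The same group in place of propyl gives a 1300-fold lower number from compound 1 to compound 3 (3.12 log units; beyond the scatter), so both steps are large and compound 3 is the strongest inhibitor of the three. Nothing available accounts for a change of this size.

The change brings in a sulfonyl, an amino hydrogen, an aromatic ring, a chlorine and a fluorine all at once, and the compounds shown do not tell which of these carries the step. A plain phenylsulfonylamino group without either halogen, or a simple amine on this carbon, would begin to separate them.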